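Fluoro for chloro on the shared core of compound 1

A few compounds are considered here, and "the series" means these few. Any claim that something is new, unique, unknown or untested is made for them only; others in the source may bear on it.

Measured compounds:
compound 1 `CC1CCN(c2c(S(=O)(=O)c3ccc(Cl)c(Cl)c3)cnc3ccc(Cl)cc23)CC1`, 86%
compound 2 `CC1CCN(c2c(S(=O)(=O)c3cccc(Cl)c3)cnc3ccc(Cl)cc23)CC1`, 92%

In an assay on isolated protein for displacement of a labelled ligand from metabotropic glutamate receptor 5 (Homo sapiens), with a stated time of 60 min, tested at 1 uM (a higher number here means more inhibition at the concentration tested (going by the name of the read-out), a lower number less inhibition), compound 1 gives 86%, the lower of the two numbers, and compound 2 gives 92%, the two lying within the scatter of each other: the step of a number 6 percentage points higher from compound 1 to compound 2 (within the scatter) is hydrogen in place of chloro on an aromatic carbon. Compound 3 `CC1CCN(c2c(S(=O)(=O)c3ccc(Cl)c(Cl)c3)cnc3ccc(F)cc23)CC1` differs from compound 1 by fluoro in place of chloro on an aromatic carbon. Within the data shown here, the one measured step sits on a different ring from this change, so nothing measured bears on it directly; the only guide is that the single change seen so far left this assay unmoved beyond the scatter. Compound 3 is therefore expected to stay close to compound 1, with a step of a number 6 percentage points lower from compound 1 to compound 3 (within the scatter) that is estimated to lie within the scatter or a little below it. The estimate for compound 3 is 80%, in a range from 58% to 95%.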

Compound 3, a percentage reported as inhibition, at one concentration (the size of the read-out at that concentration, not a potency) in the metabotropic glutamate receptor 5 assay: 91%
Beside the measured number, compound 3's estimate is 11 percentage points below it, and the stated range covers the measured number.
By their numbers in the metabotropic glutamate receptor 5 assay, from the lowest: compounds 1, 3 and 2 (each within the scatter of the next).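

In the metabotropic glutamate receptor 5 assay, fluoro in place of chloro on the core gives a number 5 percentage points higher from compound 1 to compound 3 (within the scatter), so a change at this place on the fused system, and not only the earlier one on the other ring, leaves the read-out within its scatter at the single concentration tested. In a physicochemical assay for solubility (on this read-out lower numbers stand for lower solubility and higher numbers for higher solubility), compound 1 gives < 3000 nM, which is a limit of the assay. In the physicochemical assay compound 3 gives < 3000 nM, which is also a limit of the assay.

The step between these two solubility entries cannot be read, so what this change does to that read-out stays open: the limit of < 3000 nM in the physicochemical assay, at which 2 of the 2 values shown sit.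

Also open, as far as these compounds go, is whether a group of another kind at this position, such as an amine or a methoxy group, would keep the inhibition seen in the metabotropic glutamate receptor 5 assay.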